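Removing a tert-butyl group from compound 2

The source may hold more compounds than are shown below. What is called first, only, known or untested is meant among the compounds shown, and "the series" means these compounds.

In a functional assay on CCRF-CEM cells (Homo sapiens) for cytotoxicity, read by cell counting, with a stated time of 3 days (a higher number here means a weaker inhibitor, a lower number a stronger inhibitor), the three measured compounds gave these numbers:
Compound 1 `C=C(Br)C(=O)Nc1ccc(/C=C2\SC(=O)N(Cc3ccc(C(C)(C)C)cc3)C2=O)cc1` gives 830 nM.
Compound 2 `CC(C)(C)c1ccc(CN2C(=O)S/C(=C\c3ccc(N)cc3)C2=O)cc1` gives 66000 nM.
Compound 3 `CC(C)(C)c1ccc(CN2C(=O)S/C(=C\c3cccc(N)c3)C2=O)cc1` gives 165000 nM.

Compound 2 stands second highest of the three. Its nearest neighbour is compound 3, reached by a 2.5-fold higher number from compound 2 to compound 3 (0.40 log units; beyond the scatter); its furthest is compound 1, from which it was reached by an 80-fold higher number from compound 1 to compound 2 (1.90 log units; beyond the scatter).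

Compound 4 `Nc1ccc(/C=C2\SC(=O)N(Cc3ccccc3)C2=O)cc1` differs from compound 2 in one place: hydrogen in place of tert-butyl on an aromatic carbon. Neither measured step touches this part of the molecule; one concerns the group on the aromatic nitrogen, the other the position of the amino group. With nothing to go on, the expected step is small, a 1.4-fold higher number from compound 2 to compound 4 (0.13 log units; within the scatter), within the scatter. Compound 4 is therefore expected at about 90000 nM, in a range from 30000 nM to 300000 nM.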

Compound 4, half-maximal inhibitory concentration: 42000 nM
For compound 4 the middle estimate is 2.1-fold (0.33 log units) above the measured one, and the stated range covers the measured number.
By their numbers in this assay, from the lowest: compound 1; then compounds 4 and 2 (each within the scatter of the next); then compound 3.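

In this assay, the step at this position is a 1.6-fold lower number from compound 2 to compound 4 (0.20 log units; within the scatter), so hydrogen on this aromatic carbon, para to a large group, serves as well as tert-butyl, and the four carbons of that group are not needed to hold the number at this level. No available evidence explains this result. As far as these compounds go, what a methyl group or a carboxylic acid would do at this position remains open, as does whether the same change would leave compound 1, with its (1-bromoethenyl)carbonyl group, as little moved.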